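The source may report more compounds than this note shows. Statements on the series, on what has been measured and on what is new or still open speak of the compounds shown alone.

In a functional assay on NCI-H23 cells (Homo sapiens) for antiproliferative activity, read by sulforhodamine B assay (on this read-out higher numbers stand for weaker inhibition of growth and lower numbers for stronger inhibition of growth), compound 1 (`CC(C)(C)CCOc1cccc(O)c1C(=O)/C=C/c1ccc(C(=O)O)cc1`) gives a measured value (4770 nM). Compound 2 (`CCCCCCOc1cccc(O)c1C(=O)/C=C/c1ccc(O)cc1`) reads > 30000 nM, which is a limit of the assay and not a number. It therefore stands at the limit, with no exact value to compare. Compound 3 (`CC(C)(C)CCOc1cccc(O)c1C(=O)/C=C/c1ccc(O)cc1`) differs from compound 2 in one place (tert-butyl in place of butyl on a saturated chain carbon, two bonds along the chain from an oxygen on an aromatic ring), with tert-butyl in place of butyl on a saturated chain carbon, two bonds along the chain from an oxygen on an aromatic ring. Compound 1 (4770 nM) also carries 3,3-dimethylbutoxy, so a moderate shift toward stronger inhibition is expected in this assay. The expected change is modest (an at least 2.0-fold lower number from compound 2 to compound 3 (0.30 log units; that floor lies within the scatter)). Compound 3 is estimated at 15000 nM (range 6000 nM to 30000 nM).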

Compound 3, concentration for 50% growth inhibition: 3130 nM
The estimate for compound 3 lay 4.8-fold (0.68 log units) above the measured number, and the stated range ends above it.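

In this assay, replacing the straight hexyloxy chain with the branched 3,3-dimethylbutoxy chain gives an at least 9.5-fold lower number from compound 2 to compound 3 (0.98 log units; beyond the scatter), so the branching of a chain made of the same atoms separates these two compounds. Compound 2 reads as a limit and not a number, so that step is only a floor: the limit of > 30000 nM in this assay, at which 1 of the 3 values shown sits.

With the branched chain in place, hydroxy in place of carboxy on the aromatic carbon gives a 1.5-fold lower number from compound 1 to compound 3 (0.18 log units; within the scatter), so these two groups are not told apart here. As far as these compounds go, whether an amine on that aromatic carbon, or a longer branched chain, would hold this level remains open.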